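A few compounds are considered here, and "the series" means these few. Any claim that something is new, unique, unknown or untested is made for them only; others in the source may bear on it.

Measured so far in an ADME assay on microsomes from liver (Mus musculus) for metabolic stability, read by LC-MS, using NADPH, tested at 10 uM; a higher number here means that the compound lasts longer, a lower number that the compound disappears faster:
- compound 1 `Cc1cc(F)ccc1S(=O)(=O)N1CCN(c2ccc(C(=O)NCc3ccc(F)cc3)nn2)CC1`; in this assay compound 1 gives 0.25 h
- compound 2 `O=C(NCc1ccc(F)cc1)c1ccc(N2CCN(S(=O)(=O)c3ccccc3C(F)(F)F)CC2)nn1`; compound 2 gives 0.517 h
- compound 3 `N#Cc1ncccc1S(=O)(=O)N1CCN(c2ccc(C(=O)NCc3ccc(F)cc3)nn2)CC1`; compound 3 gives 0.0833 h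

Compound 3 stands lowest of the three numbers: a 3.0-fold lower number from compound 1 to compound 3 (0.48 log units; beyond the scatter) and a 6.2-fold lower number from compound 2 to compound 3 (0.79 log units; beyond the scatter). Between the other two, a 2.1-fold higher number from compound 1 to compound 2 (0.32 log units; beyond the scatter).

Compound 4 `Cc1ncccc1S(=O)(=O)N1CCN(c2ccc(C(=O)NCc3ccc(F)cc3)nn2)CC1` differs from compound 3 in one place: methyl in place of cyano on an aromatic carbon. Within the data shown here, no measured step exchanges cyano for methyl on the same ring. The nearest comparison is compound 1, which carries its methyl on a 4-fluoro-2-methylphenyl rather than on a 2-cyanopyridin-3-yl; there the step of a 3.0-fold lower number from compound 1 to compound 3 (0.48 log units; beyond the scatter) was modest and ran downward toward compound 3. Compound 4 keeps the ring of compound 3 but takes the methyl of compound 1, so a modest rise from compound 3 is expected, though it may remain within the scatter. Compound 4 is therefore expected to show a 1.8-fold higher number from compound 3 to compound 4 (0.26 log units; within the scatter). Compound 4 is estimated at 0.15 h, with a range of 0.06 h to 0.35 h.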

Compound 4, half-life: 0.133 h
For compound 4 the middle estimate is 1.1-fold (0.05 log units) above the measured one; measured number inside the range.
By their numbers in this assay, from the lowest: compounds 3, 4 and 1 (each within the scatter of the next, the first and the last beyond it); then compound 2.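

In this assay, the change from 2-cyanopyridin-3-yl to 2-methylpyridin-3-yl gives a 1.6-fold higher number from compound 3 to compound 4 (0.20 log units; within the scatter), so nitrile and methyl are not told apart at this position, next to the ring nitrogen. With the methyl in place, the change of aryl group gives a 1.9-fold lower number from compound 1 to compound 4 (0.27 log units; within the scatter), which also does not separate the two, whereas a 3.9-fold lower number from compound 2 to compound 4 (0.59 log units; beyond the scatter) keeps compound 2 apart from the other three compounds. No measurement on these compounds accounts for these numbers.

Still open, as far as these compounds go, is how an amine or a methoxy group would read at this same position on the ring. From the compounds shown here alone, it is also open whether a trifluoromethyl on this ring would give a number closer to that of compound 2 than to those of compound 3 and compound 4.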